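This account rests on a few compounds, and the source may have more. Where it says the series, first, only, none or still open, it means among the compounds named here.

Among the compounds with values here, compound 1 `O=[N+]([O-])c1ccc(Nc2nccc(-c3ccc(F)cc3)n2)cc1` is one of two compounds measured in a functional assay on MCF7 cells (Homo sapiens) for antiproliferative activity, read by MTT assay; on this read-out lower numbers stand for stronger inhibition and higher numbers for weaker inhibition. In this assay compound 1 gives 400 nM, the lowest of the two numbers. The other measured compound, compound 2 `COc1cccc(Nc2nccc(-c3ccc(Br)cc3)n2)c1`, gives 278000 nM in this assay, a far higher number that lies beyond the scatter; it differs from compound 1 in more than one place, so its two values show only that it is much weaker. Compound 3 `COc1ccc(-c2ccnc(Nc3ccc([N+](=O)[O-])cc3)n2)cc1` has not yet been measured. It differs from compound 1 in one place: methoxy in place of fluoro on an aromatic carbon, on an aromatic carbon of a six-membered aromatic ring of carbon only, para to a large group. Within the data shown here, with no single-point step among the measured compounds to lean on, the step from compound 1 to compound 3 is expected to be small and toward a higher number, not far beyond the scatter, a 2.0-fold higher number from compound 1 to compound 3 (0.30 log units; within the scatter). Compound 3 is therefore estimated at 800 nM in this assay, within a range from 200 nM to 4000 nM.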

Compound 3, half-maximal inhibitory concentration: 770 nM
Compound 3: middle estimate off by 1.0-fold (0.02 log units), on the high side; measured number inside the range.
By their numbers in this assay, from the lowest: compounds 1 and 3 (each within the scatter of the next); then compound 2.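

Methoxy in place of fluoro on an aromatic carbon, para to a large group, gives, in this assay, a 1.9-fold higher number from compound 1 to compound 3 (0.28 log units; within the scatter). Within the data shown here, this is the first single-place comparison in the set, and it shows that 4-fluorophenyl can give way to 4-methoxyphenyl on the shared core without a change beyond the scatter, even though the entering group has one more heavy atom and a hydrogen-bond acceptor. No measurement at hand offers a reason for this result.

The compounds shown leave open whether this position would accept an amine, a carboxylic acid or a longer chain equally well. They also leave open how much of the large gap to compound 2 comes from this position and how much from the other place in which it differs.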